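The source may hold more compounds than are shown below. What is called first, only, known or untested is meant among the compounds shown, and "the series" means these compounds.

Measured compounds:
- compound 1, `O=C(NO)c1ccc(NCc2nc(-c3ccccn3)nn2-c2ccccc2)cc1`: 58.6%
- compound 2, `NNC(=O)c1ccc(NCc2nc(-c3ccccc3)nn2-c2ccccc2)cc1`: 10%

Compound 1 was tested in an assay on Sf9 cells for inhibition of protein deacetylase HDAC6 (Homo sapiens), read by fluorescence, with a stated time of 40 min, tested at 100 nM (on this read-out higher numbers stand for more inhibition at the one concentration tested (going by the name of the read-out) and lower numbers for less inhibition), and gives 58.6% there. Compound 2 gives 10% in this assay. Of these two numbers, compound 1 stands highest, and the gap to compound 2 is beyond the usual scatter of such measurements, so the two compounds are genuinely set apart on this read-out. Within the data shown here, no single-change step between measured compounds is available, so nothing measured tells directly how a change of one aromatic group on the core of compound 1 plays out.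

Compound 3 is `O=C(NO)c1ccc(NCc2nc(-c3ccsc3)nn2-c2ccccc2)cc1` and has not yet been measured in this assay. It differs from compound 1 as follows: thiophen-3-yl in place of pyridin-2-yl on an aromatic carbon. The hydroxamic acid part of compound 1, which is the part shared with compound 3, is kept unchanged. Among the measured compounds shown here, with no measured step to rest on, the expectation is for a step of a number 8.6 percentage points lower from compound 1 to compound 3 (within the scatter) that stays within the usual scatter, with no clear direction. For compound 3 the estimated value in this assay is therefore 50%, expected to fall between 25% and 75%.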

Compound 3, a percentage reported as inhibition, at one concentration (the size of the read-out at that concentration, not a potency): 53.4%
For compound 3 the middle estimate is 3.4 percentage points below the measured one; measured number inside the range.
By their numbers in this assay, from the lowest: compound 2; then compounds 3 and 1 (each within the scatter of the next).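

In this assay, among these compounds, the pyridin-2-yl on this aromatic carbon, the ring atom between two ring nitrogen atoms of the shared core, gives way to thiophen-3-yl, and the step reads a number 5.2 percentage points lower from compound 1 to compound 3 (within the scatter) and so gives the first direct look at this position. A six-membered aromatic ring carrying a ring nitrogen can thus be exchanged here for a five-membered aromatic ring carrying a sulfur without a difference that this read-out can tell from ordinary scatter, so the ring nitrogen of pyridin-2-yl is not needed at this position to keep the inhibition seen at the one concentration tested. Nothing available here explains this result.

What the compounds shown leave open is whether a group of another kind on this same carbon, such as cyclohexyl, an amine or a carboxylic acid, would leave the number just as undisturbed. Going by these compounds, because each compound was read at a single concentration, it also remains open whether compound 1 and compound 3 would match across a full range of concentrations.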